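The source may report more compounds than this note shows. Statements on the series, on what has been measured and on what is new or still open speak of the compounds shown alone.

Compound 1 `COc1ccc(/C=C2\CN(C(=S)SCc3cn(Cc4ccccc4Cl)nn3)C/C(=C\c3ccc(OC)cc3)C2=O)cc1`: in a functional assay on MDA-MB-231 cells (Homo sapiens) for cytotoxicity, read by MTT assay, with a stated time of 24 h (on this read-out higher numbers stand for weaker inhibition and lower numbers for stronger inhibition), compound 1 gives > 100000 nM, a limit of the assay.
Compound 2 `Cc1ccc(/C=C2\CN(C(=S)SCc3cn(Cc4ccccc4Cl)nn3)C/C(=C\c3ccc(C)cc3)C2=O)cc1`: in this assay compound 2 gives 93200 nM.

Compound 1 stands at the limit of > 100000 nM in this assay, at which 1 of the 2 values shown sits, so no number is known for it. Compound 3 `COc1ccc(/C=C2\CN(C(=S)SCc3cn(Cc4cccc(Cl)c4)nn3)C/C(=C\c3ccc(OC)cc3)C2=O)cc1` differs from compound 1 in one place: 3-chlorophenyl in place of 2-chlorophenyl on a saturated chain carbon bound to an aromatic nitrogen. Going by the values given here, no measured pair rests on such a change. Neither compound 1 nor compound 2 shows strong inhibition in this assay, and there is no ground to expect a shift beyond the scatter in either direction. Compound 3 is expected to give 100000 nM, with an estimated range from 40000 nM to 300000 nM. The expected step is a number no higher from compound 1 to compound 3 (the limit leaves the size open).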

Compound 3, half-maximal inhibitory concentration: 32000 nM
The estimate for compound 3 lay 3.1-fold (0.49 log units) above the measured number; measured number below the stated range.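

In this assay, 3-chlorophenyl in place of 2-chlorophenyl on a saturated chain carbon bound to an aromatic nitrogen gives an at least 3.1-fold lower number from compound 1 to compound 3 (0.49 log units; beyond the scatter). Going by these compounds alone, this is the first sign that the read-out responds at this position, and it does so to a change that leaves the atoms the same and joins them differently. The size of the step stays open because the value of compound 1 is a limit: the limit of > 100000 nM in this assay, at which 1 of the 3 values shown sits.

As far as these compounds go, whether 4-chlorophenyl, plain phenyl or 3-methoxyphenyl at this position would lower the number further remains open. So does whether 3-chlorophenyl would have a similar effect on the core of compound 2.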